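Swapping a Fluorinated Aryl Ether for a Brominated One

The compounds below may be only part of what the source reports. "The series", "measured", "known", "first", "only" and "open" are said of these compounds alone.

The series shares one core, seen in compound 1 `NC1=NC2(CCSCC2)N(OCCCOc2ccc(Cl)c(Cl)c2)C(N)=N1`, which in a functional assay on HepG2 cells (Homo sapiens) for antiproliferative activity, read by MTT assay, with a stated time of 72 h (on this read-out lower numbers stand for stronger inhibition and higher numbers for weaker inhibition), gives 70 nM. Compound 2 `NC1=NC2(CCOCC2)N(OCCCOc2ccc(F)cc2)C(N)=N1` carries a different saturated ring and a different aryl ether, and in this assay compound 2 gives "not determined" (no result reported), so it stands without a number among the measured compounds. Compound 3 `NC1=NC2(CCOCC2)N(OCCCOc2cccc(Br)c2)C(N)=N1` is its nearest neighbour: 3-bromophenyl in place of 4-fluorophenyl on an oxygen on a saturated carbon. Among the compounds with values here, since no measured pair shows this change, no size of step in this assay can be stated for it, and without a number for compound 2 the expectation can lean only on compound 1. Compound 3 is therefore expected to fall in the same broad region as compound 1, with an estimate of 150 nM and a range from 40 nM to 600 nM in this assay.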

Compound 3, half-maximal inhibitory concentration: 320 nM
Compound 3: the middle estimate sits 2.1-fold (0.33 log units) below what was measured, within the range that was stated.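

In this assay, within the data shown here, compound 2 stands at "not determined" (no result reported) and so no step to compound 3 can be read. The compounds shown leave open what the change from 4-fluorophenyl to 3-bromophenyl does on its own. No supporting data bear on this result.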